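The compounds below may be only part of what the source reports. "The series", "measured", "known", "first", "only" and "open" are said of these compounds alone.

Of the compounds shown here, two have so far been measured in an ADME assay on BaF3 cells (Mus musculus) for cytotoxicity; a higher number here means that more compound is needed for the effect, a lower number that less compound is needed. Compound 1, `CC(C)Cn1cc(-c2cc(Nc3ccc(OC(F)(F)F)cc3)ncn2)cn1`, is one of them; in this assay compound 1 gives > 10000 nM, which is a limit of the assay and not a number. Compound 2, `CCCn1cc2c(Nc3ccc(OC(F)(F)F)cc3)ncnc2n1`, is the other; in this assay compound 2 gives > 10000 nM, again a limit and not a number. Compound 2 therefore stands at the edge of what the assay can report, and the same is true of the limit of > 10000 nM in this assay, at which 2 of the 2 values shown sit, where both values shown sit. Among the measured compounds shown here, no step between measured compounds is available, so there is no measured change to lean on.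

Compound 3, `FC(F)(F)Oc1ccc(Nc2ncnc3nn(C4CCCCC4)cc23)cc1`, differs from compound 2 in one place, cyclohexyl in place of propyl on an aromatic nitrogen. With nothing measured to guide it, the step expected from compound 2 to compound 3 is a step that the limit leaves unreadable from compound 2 to compound 3, that is, none beyond the usual scatter. For compound 3 the estimate in this assay is 12000 nM, with a range from 4000 nM to 40000 nM, and the assay will most likely again report only a limit.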

Compound 3, half-maximal effective concentration: > 10000 nM
Compound 3: a limit, no number; the forecaster's own chance of this, stated with the estimate: 75%; the middle value does not contradict the limit.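

Among the compounds shown here, the change from propyl to cyclohexyl on an aromatic nitrogen, which separates compound 2 from compound 3, gives no step that can be read, because both results are limits and not numbers: the limit of > 10000 nM in this assay, at which 3 of the 3 values shown sit.

The compounds shown leave open how much of compound 1, compound 2 or compound 3 is needed for the effect in this assay, and whether the group on that nitrogen changes this amount at all.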